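The source may hold more compounds than are shown below. What is called first, only, known or untested is meant among the compounds shown, and "the series" means these compounds.

Compound 1 `Cc1cc(NC(=O)Cn2nnc(-c3ccccc3)n2)n(C2CCCCC2)n1` gives 96 nM
Compound 2 `Cc1cc(NC(=O)Cn2nnc(-c3ccccc3)n2)n(C(C)C)n1` gives 556 nM

In an assay on HEK293 cells for activation of Kir3.1/Kir3.2 (Homo sapiens), read by thallium flux (on this read-out lower numbers stand for an effect already at smaller amounts and higher numbers for an effect only at larger amounts of compound), compound 1 holds the lower of the two numbers, and the move to compound 2 is a 5.8-fold higher number from compound 1 to compound 2 (0.76 log units; beyond the scatter). Compound 3 `CCC(C)n1nc(C)cc1NC(=O)Cn1nnc(-c2ccccc2)n1` differs from compound 1 by sec-butyl in place of cyclohexyl on an aromatic nitrogen. Among the compounds with values here, the only step that bears on this change, a 5.8-fold higher number from compound 1 to compound 2 (0.76 log units; beyond the scatter), also replaced the cyclohexyl with an open chain on the same aromatic nitrogen and gave a modest loss, so a loss of similar or somewhat smaller size is expected here. Compound 3 is therefore estimated at 250 nM, with a range from 100 nM to 700 nM, which means an expected step of a 2.6-fold higher number from compound 1 to compound 3 (0.42 log units; beyond the scatter).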

Compound 3, half-maximal effective concentration: > 5000 nM
Compound 3: a limit, no number (the forecaster's own chance of this, stated with the estimate: 5%); middle value at least 20-fold (1.30 log units) from the limit.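

In this assay compound 3 gives no number, only a limit: the limit of > 5000 nM in this assay, at which 1 of the 3 values shown sits.

Replacing cyclohexyl with sec-butyl gives an at least 52-fold higher number from compound 1 to compound 3 (1.71 log units; beyond the scatter), while a methyl in place of hydrogen on the isopropyl chain gives an at least 8.9-fold higher number from compound 2 to compound 3 (0.95 log units; beyond the scatter). At this aromatic nitrogen, then, one added methyl can cost more than the change from cyclohexyl to isopropyl, so the read-out does not shift gradually across these three groups.

Going by these compounds, it remains open whether a cyclopentyl ring or a straight butyl chain would stay close to compound 1 or fall away like compound 3. The reason for the sharp loss also remains unknown.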